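Methoxy in place of bromo on compound 2

The source may report more compounds than this note shows. Statements on the series, on what has been measured and on what is new or still open speak of the compounds shown alone.

In a functional assay on HCT-116 cells (Homo sapiens) for cytotoxicity, read by MTT assay (a lower number here means a stronger inhibitor, a higher number a weaker inhibitor), compound 2 (`Nc1ccccc1NC(=O)c1ccc(CNc2nc3ccc(Br)cc3s2)cc1`) gives 400 nM and compound 1 (`CSc1nc(NCc2ccc(C(=O)Nc3ccccc3N)cc2)n[nH]1`) gives 600 nM, two values within the scatter of each other. Compound 3 (`Cn1ccnc1SCc1ccc(C(=O)Nc2ccccc2N)cc1`) stands apart at 5000 nM, a higher number than either and beyond the scatter.

Compound 4 (`COc1ccc2nc(NCc3ccc(C(=O)Nc4ccccc4N)cc3)sc2c1`), not yet measured, differs from compound 2 in one place: methoxy in place of bromo on an aromatic carbon. In words, methoxy stands in place of bromo on an aromatic carbon of a six-membered aromatic ring of carbon only.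

Within the data shown here, only one measured step is available: an 8.3-fold higher number from compound 1 to compound 3 (0.92 log units; beyond the scatter). That step is beyond the scatter, but it exchanges the whole group on a saturated chain carbon, (1-methyl-1H-imidazol-2-yl)sulfanyl in place of (5-(methylsulfanyl)-1H-1,2,4-triazol-3-yl)amino. It lies at another place and is a far larger replacement, so it bears on the present change only weakly. The series holds no measured swap on this aromatic carbon, and the data favour no direction.

For compound 4 the expected step is a 1.3-fold higher number from compound 2 to compound 4 (0.10 log units; within the scatter), which is not expected to go beyond the scatter. Compound 4 is estimated at 500 nM, with an expected range of 200 nM to 1300 nM.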

Compound 4, half-maximal inhibitory concentration: 200 nM
The estimate for compound 4 lay 2.5-fold (0.40 log units) above the measured number, within the range that was stated.
By their numbers in this assay, from the lowest: compounds 4, 2 and 1 (each within the scatter of the next, the first and the last beyond it); then compound 3.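

In this assay, among these compounds, the exchange of bromo for methoxy on the aromatic carbon gives a 2.0-fold lower number from compound 2 to compound 4 (0.30 log units; within the scatter) and provides the only measured step at this position. The step exchanges a single bromine atom without hydrogen-bond acceptors for methoxy, with 2 heavy atoms and 1 hydrogen-bond acceptor, yet the two compounds cannot be told apart in this assay. This position on the six-membered aromatic ring of carbon only therefore accepts both groups without a step beyond the scatter, which the earlier exchange on the saturated chain carbon could not show. No measured property or other information accounts for this step, so the notes assign it no cause.

The compounds shown give only two groups on this aromatic carbon, so it remains open whether a primary amine, a carboxylic acid or a longer alkoxy chain would also stay within the scatter of compound 2. On these data alone, it also remains open whether methoxy in place of bromo would give a similar step on a different core, since compound 1 and compound 3 carry neither group.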